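Replacing an aryl sulfone by a cyclohexyl sulfone

A few compounds are considered here, and "the series" means these few. Any claim that something is new, unique, unknown or untested is made for them only; others in the source may bear on it.

Measured compounds:
- compound 1 `Cc1c(Cc2ccc(C(F)(F)F)cc2S(=O)(=O)c2ccccc2)c2c(n1CC(=O)O)CCNC2=O`: 13 nM
- compound 2 `CNC(=O)c1cccc(S(=O)(=O)c2ccccc2Cc2c3c(n(CC(=O)O)c2C)CCNC3=O)c1`: 240 nM

Of the compounds shown here, two have been measured in a functional assay on CHO.K1 cells for antagonist activity at prostaglandin D2 receptor 2 (Homo sapiens), read by GTPgammaS binding, with a stated time of 1 h; on this read-out lower numbers stand for stronger inhibition and higher numbers for weaker inhibition. Compound 1 gives 13 nM, while compound 2 gives 240 nM, so compound 2 stands at the higher of the two numbers, and the gap between the two values is beyond the scatter. Compound 1 and compound 2 differ in more than one place, so the two values alone do not say which part of the structure accounts for the gap.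

Compound 3 `Cc1c(Cc2ccccc2S(=O)(=O)C2CCCCC2)c2c(n1CC(=O)O)CCNC2=O` has not yet been measured. It is derived from compound 2 by a single change: cyclohexyl in place of 3-(methylcarbamoyl)phenyl on a sulfonyl sulfur. Going by the values given here, no measured pair in this set isolates such a change, so the expectation for compound 3 rests only on the position of compound 2 and on the fact that compound 1, with a plain phenyl on the same sulfur, gives 13 nM. A modest move toward a lower number is expected for compound 3, with the step of a 2.4-fold lower number from compound 2 to compound 3 (0.38 log units; beyond the scatter) regarded as uncertain. Compound 3 is therefore estimated at 100 nM, within a range of 25 nM to 400 nM.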

Compound 3, half-maximal inhibitory concentration: 28 nM
For compound 3 the middle estimate is 3.6-fold (0.55 log units) above the measured one; low and high end bracket the measured number.
By their numbers in this assay, from the lowest: compound 1; then compound 3; then compound 2.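

Going by these compounds alone, putting cyclohexyl in place of 3-(methylcarbamoyl)phenyl on the sulfonyl sulfur gives an 8.6-fold lower number from compound 2 to compound 3 (0.93 log units; beyond the scatter) in this assay, the first comparison that isolates this position. The sulfur therefore does not need an aromatic ring to reach a low number here, and compound 3 reaches its value with a six-membered non-aromatic ring of carbon only, with no hydrogen-bond donor or acceptor in the group. Nothing available explains why the number falls with this change.

The change swaps the ring and removes the methylcarbamoyl group at once, so the step cannot separate the two, and compound 1, which differs from compound 3 in more than one place, cannot settle this, since it also carries a trifluoromethyl group. The compounds shown also leave open how the number would respond on the same sulfur to a cyclopentyl ring, to an open chain such as isopropyl, or to a cyclohexyl ring carrying an amine or a carboxylic acid.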